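Working notes: a further methoxy on compound 3

A few compounds are considered here, and "the series" means these few. Any claim that something is new, unique, unknown or untested is made for them only; others in the source may bear on it.

Measured so far in a functional assay on SH-SY5Y cells (Homo sapiens) for cytotoxicity, read by MTT assay, with stated times of 24 h and 4 h; on this read-out lower numbers stand for an effect already at smaller amounts and higher numbers for an effect only at larger amounts of compound:
compound 1 `COc1cc(CNC(=O)/C=C/c2ccccc2)ccc1O`: 3660 nM
compound 2 `COc1cc(CNC(=O)/C=C/c2ccccc2O)ccc1O`: 9760 nM
compound 3 `COc1cc(CNC(=O)/C=C/c2ccccc2OC)ccc1O`: 5980 nM

Compound 3 at 5980 nM lies within the scatter of both other compounds, as a 1.6-fold higher number from compound 1 to compound 3 (0.21 log units; within the scatter) and a 1.6-fold lower number from compound 2 to compound 3 (0.21 log units; within the scatter) show. Compound 4 `COc1cc(CNC(=O)/C=C/c2cccc(OC)c2OC)ccc1O` differs from compound 3 by methoxy in place of hydrogen on an aromatic carbon, ortho to a methoxy group. Within the data shown here, the closest precedent is the same replacement, a 1.6-fold higher number from compound 1 to compound 3 (0.21 log units; within the scatter), while the hydroxy replacement, a 2.7-fold higher number from compound 1 to compound 2 (0.43 log units; beyond the scatter), is modest. No step beyond the scatter is therefore expected in this assay, and any drift would be upward. The estimated step, a 1.2-fold higher number from compound 3 to compound 4 (0.07 log units; within the scatter), is expected to stay small. Compound 4 is expected at 7000 nM, within an estimated range of 3000 nM to 16000 nM overall.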

Compound 4, half-maximal effective concentration: 5490 nM
Compound 4: middle estimate off by 1.3-fold (0.11 log units), on the high side; the measured number falls inside the stated range.
By their numbers in this assay, from the lowest: compounds 1, 4, 3 and 2 (each within the scatter of the next, the first and the last beyond it).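

In this assay the further methoxy, ortho to a methoxy group, gives a 1.1-fold lower number from compound 3 to compound 4 (0.04 log units; within the scatter) and so adds a second methoxy step that stays within the scatter. Together with a 1.6-fold higher number from compound 1 to compound 3 (0.21 log units; within the scatter) this shows that methoxy has twice replaced hydrogen on this ring with no step beyond the scatter. Nothing measured here offers an explanation for this result.

Still open, going by these compounds, is whether an amine, a carboxylic acid or a longer chain in this same place would give a step beyond the scatter. Also open, on these data alone, is whether a methoxy with no methoxy group ortho to it would behave the same way.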